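Phenyl in Place of Ethyl: Vero Cell Cytotoxicity

This account rests on a few compounds, and the source may have more. Where it says the series, first, only, none or still open, it means among the compounds named here.

Measured compounds:
- compound 1, `CCN1CCN(c2nc(Cl)nc3c2ncn3CCNc2ccnc3cc(Cl)ccc23)CC1`: in an ADME assay on Vero cells (Chlorocebus sabaeus) for cytotoxicity, read by neutral red uptake, with a stated time of 48 h (on this read-out lower numbers stand for stronger inhibition and higher numbers for weaker inhibition), compound 1 gives only a limit, > 10100 nM.
- compound 2, `Clc1ccc2c(NCCn3cnc4c(N5CCN(c6ccccc6)CC5)nc(Cl)nc43)ccnc2c1`: in this assay compound 2 gives 4040 nM.
- compound 3, `CCN1CCN(c2nc(Cl)nc3c2ncn3CCCNc2ccnc3cc(Cl)ccc23)CC1`: in this assay compound 3 gives only a limit, > 9830 nM.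

Compound 4, `Clc1ccc2c(NCCCn3cnc4c(N5CCN(c6ccccc6)CC5)nc(Cl)nc43)ccnc2c1`, is not yet measured. It differs from compound 3 by phenyl in place of ethyl on an amine nitrogen in a ring. The same change, (phenyl in place of ethyl on an amine nitrogen in a ring), turns compound 1 into compound 2, and there it gives an at least 2.5-fold lower number from compound 1 to compound 2 (0.39 log units; beyond the scatter). That step is known only as a bound because compound 1 sits at the limit of > 10100 nM in this assay, at which 1 of the 3 values shown sits. How the core of compound 1 differs from the core of compound 3 is not broken down here. Compound 3 sits at the limit of > 9830 nM in this assay, at which 1 of the 3 values shown sits. From compound 3 to compound 4 a step of an at least 2.1-fold lower number from compound 3 to compound 4 (0.33 log units; beyond the scatter) is expected, resting on an at least 2.5-fold lower number from compound 1 to compound 2 (0.39 log units; beyond the scatter). Compound 4 is therefore estimated at 4500 nM in this assay, likely between 2000 nM and 10000 nM.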

Compound 4, half-maximal inhibitory concentration: > 8900 nM
Compound 4: no number, only a limit (the forecaster's own chance of this, stated with the estimate: 35%); middle value at least 1.9-fold (0.29 log units) away from the limit.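

Compound 3 and compound 4 both give only limits, not numbers, so the step between them cannot be read. Going by these compounds, whether phenyl in place of ethyl lowers the number on compound 3, as it does on compound 1, stays open.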